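A few compounds are considered here, and "the series" means these few. Any claim that something is new, unique, unknown or untested is made for them only; others in the source may bear on it.

Compound 1 `C=C/C=C\[C@H](C)[C@H](OC(N)=O)[C@@H](C)[C@H](O)[C@@H](C)C/C(C)=C\[C@H](C)[C@@H](O)[C@@H](C)/C=C\CCc1ccccc1` — in a functional assay on MCF7 cells (Homo sapiens) for cytotoxicity (a lower number here means a stronger inhibitor, a higher number a weaker inhibitor), compound 1 gives 480 nM.
Compound 2 `C=C/C=C\[C@H](C)[C@H](OC(N)=O)[C@@H](C)[C@H](O)[C@@H](C)C/C(C)=C\[C@H](C)[C@@H](O)[C@@H](C)/C=C\CCc1cccc(O)c1C` — in this assay compound 2 gives 490 nM.
Compound 3 `C=C/C=C\[C@H](C)[C@H](OC(N)=O)[C@@H](C)[C@H](O)[C@@H](C)C/C(C)=C\[C@H](C)[C@@H](O)[C@@H](C)/C=C\CCc1cc(F)cc(F)c1` — in this assay compound 3 gives 600 nM.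

Compound 3 carries the largest of the three numbers, yet the steps of a 1.3-fold higher number from compound 1 to compound 3 (0.10 log units; within the scatter) and a 1.2-fold higher number from compound 2 to compound 3 (0.09 log units; within the scatter) both lie within the scatter, so the three compounds cannot be told apart.

Compound 4 `C=C/C=C\[C@H](C)[C@H](OC(N)=O)[C@@H](C)[C@H](O)[C@@H](C)C/C(C)=C\[C@H](C)[C@@H](O)[C@@H](C)/C=C\CCc1sccc1C` differs from compound 3 in one place: 3-methylthiophen-2-yl in place of 3,5-difluorophenyl on a saturated chain carbon, two bonds along the chain from a double-bonded chain carbon. For the measured compounds named here, every measured step so far exchanged the aromatic group at this same place, and each stayed within the scatter: a 1.0-fold higher number from compound 1 to compound 2 (0.01 log units; within the scatter), a 1.3-fold higher number from compound 1 to compound 3 (0.10 log units; within the scatter), a 1.2-fold higher number from compound 2 to compound 3 (0.09 log units; within the scatter). Going by the values given here, no measured step replaces a six-membered ring with a five-membered one holding a sulfur atom, so the evidence is thin. Still, for compound 4 a step within the scatter is expected, a 1.1-fold lower number from compound 3 to compound 4 (0.04 log units; within the scatter). Compound 4 is therefore estimated at 550 nM, within a range of 250 nM to 1200 nM.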

Compound 4, half-maximal inhibitory concentration: 370 nM
Beside the measured number, compound 4's estimate is 1.5-fold (0.17 log units) above it; measured number inside the range.
By their numbers in this assay, from the lowest: compounds 4, 1, 2 and 3 (each within the scatter of the next).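

In this assay a five-membered aromatic ring with sulfur, 3-methylthiophen-2-yl, does as well at this place as the six-membered rings: the steps of a 1.6-fold lower number from compound 3 to compound 4 (0.21 log units; within the scatter) and a 1.3-fold lower number from compound 2 to compound 4 (0.12 log units; within the scatter) and also a 1.3-fold lower number from compound 1 to compound 4 (0.11 log units; within the scatter) all stay small. Across these four compounds, then, neither ring size nor the ring's atoms shift the number beyond the scatter. No measurement here offers an explanation. Still open, going by these compounds, is whether an amine or a carboxylic acid on this chain would move the number. A longer chain before the ring is equally untested in the compounds shown.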